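The source may hold more compounds than are shown below. What is called first, only, known or untested is meant among the compounds shown, and "the series" means these compounds.

Series notes. Three compounds of one shared core carry a substituted phenyl on the amide-type nitrogen: compound 1 `COc1cc(-c2cc(C(=O)O)c3ccccc3n2)ccc1OCC(=O)Nc1cccc(C)c1`, compound 2 `COc1cc(-c2cc(C(=O)O)c3ccccc3n2)ccc1OCC(=O)Nc1ccc(C)cc1` and compound 3 `COc1cc(-c2cc(C(=O)O)c3ccccc3n2)ccc1OCC(=O)Nc1ccc(Cl)cc1`. In a physicochemical assay for lipophilicity, using the shake flask method, in phosphate buffer, measured as octanol-water partition, at pH 7.4 (on this read-out higher numbers stand for higher lipophilicity and lower numbers for lower lipophilicity), compound 1 gives 1.5, compound 2 gives 1.2 and compound 3 gives 1.5. The steps among them are all small: a number 0.30 log units lower from compound 1 to compound 2 (within the scatter), no change at the digits printed from compound 1 to compound 3 (within the scatter), a number 0.30 log units higher from compound 2 to compound 3 (within the scatter). Compound 3 therefore stands level with compound 1 at the digits given, the two together at the top of the three numbers, with compound 2 the furthest from it.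

Compound 4 `COc1cc(-c2cc(C(=O)O)c3ccccc3n2)ccc1OCC(=O)Nc1ccc(C(F)(F)F)cc1` is not yet measured. It differs from compound 3 by trifluoromethyl in place of chloro on an aromatic carbon. Among the compounds with values here, no measured step covers a chloro to trifluoromethyl exchange; the nearest are the exchanges on the same aromatic carbon, a number 0.30 log units higher from compound 2 to compound 3 (within the scatter) and no change at the digits printed from compound 1 to compound 3 (within the scatter), both inside the scatter. A small upward step in this assay is expected, a number 0.30 log units higher from compound 3 to compound 4 (within the scatter), which may stay inside the scatter. Compound 4 is estimated at 1.8, in the range 1.4 to 2.2.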

Compound 4, distribution coefficient: 1.6
Compound 4: middle estimate off by 0.20 log units, on the high side; low and high end bracket the measured number.
By their numbers in this assay, from the lowest: compounds 2, 1, 3 and 4 (each within the scatter of the next, the first and the last beyond it).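

In this assay, within the data shown here, trifluoromethyl on the aromatic carbon para to a large group gives the first step that lies beyond the scatter, though a modest one, against methyl at the same carbon (a number 0.40 log units higher from compound 2 to compound 4 (beyond the scatter)). Chloro and trifluoromethyl cannot be told apart at this carbon (a number 0.10 log units higher from compound 3 to compound 4 (within the scatter)), although the entering group has 4 heavy atoms and the leaving group 1. The 4-(trifluoromethyl)phenyl and 3-methylphenyl groups on the amide-type nitrogen cannot be told apart either (a number 0.10 log units higher from compound 1 to compound 4 (within the scatter)).

Nothing available here accounts for these steps. On these data alone, it remains open whether a nitrile, a hydroxyl or an amine on this same aromatic carbon would give a step beyond the scatter from chloro, and how far such a group would move the number.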